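The compounds below may be only part of what the source reports. "The series", "measured", "known", "first", "only" and "open" are said of these compounds alone.

Working notes on the series. The shared core is that of compound 1 `CC(/C=N/Nc1ccc([N+](=O)[O-])cc1)=N\NC(=O)c1ccccc1`. In a functional assay on cells (Splenocyte, Mus musculus, strain BALB/c) for inhibition, read by scintillation counting and thymidine incorporation, with a stated time of 72 h (on this read-out higher numbers stand for weaker inhibition and lower numbers for stronger inhibition), compound 1 gives only a limit of the assay, > 12000 nM. Compound 2 `CC(/C=N/Nc1ccc([N+](=O)[O-])cc1)=N\NC(=O)c1ccccc1O` gives 1640 nM in this assay, and compound 3 `CC(/C=N/Nc1ccc([N+](=O)[O-])cc1)=N\NC(=O)c1ccccc1C` gives 6000 nM. The steps of an at least 7.3-fold lower number from compound 1 to compound 2 (0.86 log units; beyond the scatter) and an at least 2.0-fold lower number from compound 1 to compound 3 (0.30 log units; that floor lies within the scatter) both rest on (the limit of > 12000 nM in this assay, at which 1 of the 3 values shown sits), so their sizes are floors only. Between the two numbered compounds the step is a 3.7-fold higher number from compound 2 to compound 3 (0.56 log units; beyond the scatter); compound 3 therefore stands highest of the two numbers given, with compound 2 nearest to it.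

Compound 4 `CC(/C=N/Nc1ccc([N+](=O)[O-])cc1)=N\NC(=O)c1ccccc1I` differs from compound 3 by iodo in place of methyl on an aromatic carbon. Among the measured compounds shown here, no measured step exchanges methyl for iodo; the steps that bear on it are an at least 2.0-fold lower number from compound 1 to compound 3 (0.30 log units; that floor lies within the scatter) and a 3.7-fold higher number from compound 2 to compound 3 (0.56 log units; beyond the scatter), which place the methyl result between the hydroxy result and the limit but give no direct guide for a halogen at that position. For compound 4 the expected step is a 1.2-fold lower number from compound 3 to compound 4 (0.08 log units; within the scatter), not beyond the scatter. The estimate for compound 4 in this assay is 5000 nM, in a range from 1500 nM to 16000 nM.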

Compound 4, half-maximal inhibitory concentration: 2980 nM
The estimate for compound 4 lay 1.7-fold (0.22 log units) above the measured number; the measured number falls inside the stated range.
By their numbers in this assay, from the lowest: compounds 2, 4 and 3 (each within the scatter of the next, the first and the last beyond it). At a limit, above all of these: compound 1.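

With iodo on this aromatic carbon, ortho to a large group, the steps of a 2.0-fold lower number from compound 3 to compound 4 (0.30 log units; within the scatter) and a 1.8-fold higher number from compound 2 to compound 4 (0.26 log units; within the scatter) leave compound 4 not separable from either neighbour in this assay, even though compound 2 and compound 3 stand apart beyond the scatter. The series now holds a group that cannot be assigned to either side of that gap, so the hydroxy and methyl results alone do not define two distinct levels at this position. The step of an at least 4.0-fold lower number from compound 1 to compound 4 (0.60 log units; beyond the scatter) clears the scatter even as a floor, which the methyl step from compound 1 did not, and its true size stays unknown since compound 1 stands at a limit: the limit of > 12000 nM in this assay, at which 1 of the 4 values shown sits.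

As far as these compounds go, whether fluoro, chloro, an amine or a carboxylic acid on the same aromatic carbon would fall with compound 2, compound 3 or compound 4 remains open. Also open, from the compounds shown here alone, is whether iodo would give a comparable result elsewhere on this ring.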